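Working notes: 4-methoxyphenyl in place of 2,4,5-trichlorophenyl

A few compounds are considered here, and "the series" means these few. Any claim that something is new, unique, unknown or untested is made for them only; others in the source may bear on it.

Measured so far in a functional assay on MDA-MB-231 cells (Homo sapiens) for antiproliferative activity, read by MTT assay, with a stated time of 72 h (on this read-out higher numbers stand for weaker inhibition and lower numbers for stronger inhibition), for this series:
- compound 1 `NC1=NC2(CCSCC2)N(OCCCOc2ccc(Br)cc2)C(N)=N1` gives 440 nM
- compound 2 `NC1=NC2(CCSCC2)N(OCCCOc2cc(Cl)c(Cl)cc2Cl)C(N)=N1` gives 110 nM
- compound 3 `NC1=NC2(CCOCC2)N(OCCCOc2ccc(Cl)cc2Cl)C(N)=N1` reads "not determined" (no result reported)

Compound 2 holds the lower of the two numbers available, and compound 3 adds no number to the comparison. Compound 4 `COc1ccc(OCCCON2C(N)=NC(N)=NC23CCSCC3)cc1` awaits measurement. It carries 4-methoxyphenyl in place of 2,4,5-trichlorophenyl on an oxygen on a saturated carbon.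

For the measured compounds named here, one measured step touches this place: a 4.0-fold lower number from compound 1 to compound 2 (0.60 log units; beyond the scatter) with 2,4,5-trichlorophenyl in place of 4-bromophenyl. Going by the values given here, no measured compound carries 4-methoxyphenyl, so this single step is the only guide, and it covers a different incoming group. Compound 1, which lacks 2,4,5-trichlorophenyl, stands at 440 nM and so suggests that losing this group costs ground. A higher number is therefore expected, with the size of the move close to the measured one. The expected change is a 3.6-fold higher number from compound 2 to compound 4 (0.56 log units; beyond the scatter) in this assay with wide uncertainty. Compound 4 is estimated at 400 nM with 130 nM to 1200 nM as the expected range.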

Compound 4, half-maximal inhibitory concentration: 350 nM
Compound 4: the middle estimate sits 1.1-fold (0.06 log units) above what was measured; the range from low to high includes it.
By their numbers in this assay, from the lowest: compound 2; then compounds 4 and 1 (each within the scatter of the next).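

With 4-methoxyphenyl as a second group to set against 2,4,5-trichlorophenyl on an oxygen on a saturated carbon, this assay shows a 3.2-fold higher number from compound 2 to compound 4 (0.50 log units; beyond the scatter) on the shared core, so the low number of compound 2 no longer rests on the comparison with 4-bromophenyl alone. Methoxy in place of bromo on an aromatic carbon gives a 1.3-fold lower number from compound 1 to compound 4 (0.10 log units; within the scatter) and this lies within the scatter, so compound 1 and compound 4 cannot be told apart, and among these three only compound 2 stands apart, with steps beyond the scatter to both others. No independent measurement accompanies these numbers, so the gap between the groups stays without an assigned reason.

The compounds shown leave open whether the low number needs all the chlorine of 2,4,5-trichlorophenyl or is also reached with a single chloro group, and how an unsubstituted phenyl, or a ring carrying a nitrile or a carboxylic acid, would read in this assay on the same core. From the compounds shown here alone, compound 3 has no number, so its different core offers no comparison, and the effect of a longer chain in place of the present one also remains open.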